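Compound 4 from compound 3: a new group on the carbonyl carbon

The source may hold more compounds than are shown below. What is called first, only, known or untested is meant among the compounds shown, and "the series" means these compounds.

Measured so far:
Compound 1, `Cc1ccsc1C(=O)OC(CCN(C)C)c1ccc(Cl)cc1`, gives 119% in an assay on NIH3T3 cells with Urotensin-2 receptor (Homo sapiens) as the target; on this read-out lower numbers stand for smaller maximal responses and higher numbers for larger maximal responses.
Compound 2, `Cc1c(Cl)cccc1C(=O)OC(CCN(C)C)c1ccc(Cl)cc1`, gives 118% in this assay.
Compound 3, `Cc1cc(Br)ccc1C(=O)OC(CCN(C)C)c1ccc(Cl)cc1`, gives 95% in this assay.

Compound 3 holds the lowest of the three numbers. Its nearest neighbour is compound 2, a number 23 percentage points lower from compound 2 to compound 3 (beyond the scatter), and compound 1 lies farthest off, a number 24 percentage points lower from compound 1 to compound 3 (beyond the scatter). The remaining pair sits close together, a number 1 percentage points lower from compound 1 to compound 2 (within the scatter).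

Compound 4, `Cc1ccccc1NC(=O)OC(CCN(C)C)c1ccc(Cl)cc1`, is not yet measured. It differs from compound 3 in one place: (2-methylphenyl)amino in place of 4-bromo-2-methylphenyl on a carbonyl carbon. Both measured steps that end in compound 3 also change the group on the carbonyl carbon, and each moved the number by a modest amount beyond the scatter, so the series shows that this position can shift the read-out. For the measured compounds named here, no measured step puts a (2-methylphenyl)amino group there, and nothing among the three compounds speaks for or against a hydrogen-bond donor at that place. For compound 4 the expected step is therefore a modest rise back toward the range of compound 1 and compound 2, a number 13 percentage points higher from compound 3 to compound 4 (beyond the scatter), with a broad margin. Compound 4 is estimated at 108%, expected between 85% and 130% in this assay.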

Compound 4, largest response reached (reported as efficacy), in percent of the reference or control that the assay uses: 176%
Beside the measured number, compound 4's estimate is 68 percentage points below it; measured number outside the range, above it.
By their numbers in this assay, from the lowest: compound 3; then compounds 2 and 1 (each within the scatter of the next); then compound 4.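

In this assay, (2-methylphenyl)amino on the carbonyl carbon gives the largest steps seen at this position, whichever group it replaces (a number 81 percentage points higher from compound 3 to compound 4 (beyond the scatter); a number 58 percentage points higher from compound 2 to compound 4 (beyond the scatter); a number 57 percentage points higher from compound 1 to compound 4 (beyond the scatter)). The first three compounds showed only modest steps here, so the position has a much wider reach on the maximal response than they suggested, and compound 4 now stands beyond the scatter above every other compound shown. The change from compound 3 brings in the hydrogen-bond donor of the (2-methylphenyl)amino group and also removes the bromine, and no measurement available here bears on what lies behind the rise.

Open, as far as these compounds go, is whether a (4-bromo-2-methylphenyl)amino group on the carbonyl carbon would stay close to compound 4 or fall back toward compound 3, which would separate the effect of the nitrogen link from that of losing the bromine. Also open, from the compounds shown here alone, is what an N-methyl-N-(2-methylphenyl)amino group, which has no hydrogen on that nitrogen, or a 2-methylphenoxy group would do to the number.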